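Working notes on a four-compound lipophilicity set

The source may report more compounds than this note shows. Statements on the series, on what has been measured and on what is new or still open speak of the compounds shown alone.

Measured in a physicochemical assay for lipophilicity, read by HPLC, in phosphate buffer, measured as octanol-water partition, with a stated time of 24 h, at pH 7.4; on this read-out lower numbers stand for lower lipophilicity and higher numbers for higher lipophilicity:
compound 1 `Clc1ccc2c(NCCNc3nccc(Cl)n3)ccnc2c1`: 0.501
compound 2 `Clc1ccc2c(NCCCNc3nccc(Cl)n3)ccnc2c1`: 0.657
compound 3 `Clc1ccc2c(NCCNc3ccnc(Cl)n3)ccnc2c1`: 0.489

Compounds 1 and 2 share the same two end groups but differ in the chain that joins them; the difference between the two cores is not broken down here, and their two values lie within the usual scatter of each other. Compound 3 arises from compound 1 by one change, (2-chloropyrimidin-4-yl in place of 4-chloropyrimidin-2-yl on an amine nitrogen), and this gave a number 0.01 log units lower from compound 1 to compound 3 (within the scatter). Compound 4 `Clc1ccc2c(NCCCNc3ccnc(Cl)n3)ccnc2c1` is not yet measured in this assay. It arises from compound 2 by the same change, (2-chloropyrimidin-4-yl in place of 4-chloropyrimidin-2-yl on an amine nitrogen), at the same kind of place. From the compounds shown here alone, the change occurs twice among the four compounds, once measured and once still open. Among the compounds with values here, since the one measured instance, a number 0.01 log units lower from compound 1 to compound 3 (within the scatter), stayed within the scatter, compound 4 is expected to sit close to compound 2, with an estimated step of a number 0.01 log units lower from compound 2 to compound 4 (within the scatter). For compound 4 the estimate in this assay is 0.65, expected to fall between 0.35 and 0.95.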

Compound 4, distribution coefficient: 0.229
Estimate against measurement, compound 4: 0.42 log units above, outside the stated range (below it).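

In this assay, putting 2-chloropyrimidin-4-yl in place of 4-chloropyrimidin-2-yl on an amine nitrogen gave a number 0.01 log units lower from compound 1 to compound 3 (within the scatter) but a number 0.43 log units lower from compound 2 to compound 4 (beyond the scatter), so the size of the step did not carry over from the core of compound 1 to the core of compound 2. This shows that, for these two cores, a step within the scatter on one core does not ensure the same on the other, but with one pair on each core it gives no rule for the series and does not show how the step would behave on any other core. Nothing in the information available explains why the two steps differ.

The compounds shown leave open whether the larger step belongs to the chain of compound 2 alone or would also appear with a longer chain. They also leave open whether the step would persist with an amine in place of the chlorine on the pyrimidine.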